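The compounds below may be only part of what the source reports. "The series", "measured", "known", "first", "only" and "open" are said of these compounds alone.

Measured so far in an ADME assay on Raji cells (Homo sapiens) for cytotoxicity, read by luminescence, with a stated time of 72 h; on this read-out higher numbers stand for an effect only at larger amounts of compound and lower numbers for an effect already at smaller amounts (both values are limits):
Compound 1 `CCOC(=O)c1c(-c2cccc(OC)c2)[nH]c2cc(Cl)c(Cl)cc2c1=O` gives > 21500 nM as a limit
Compound 2 `CCOC(=O)c1c(-c2cccc(-c3ccccc3)c2)[nH]c2cc(OC)c(Cl)cc2c1=O` gives > 21500 nM as a limit

Compound 2 stands at > 21500 nM as a limit of the assay and not a number. Both measured compounds sit at the same point (the limit of > 21500 nM in this assay, at which 2 of the 2 values shown sit) and so no size of step can be read from them.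

Compound 3 `CCOC(=O)c1c(-c2cccc(OC)c2)[nH]c2cc(OC)c(Cl)cc2c1=O` follows from compound 2 with methoxy in place of phenyl on an aromatic carbon, meta to a large group (methoxy in place of phenyl on an aromatic carbon). In this assay no step beyond the scatter is expected in either direction, with compound 2 at its limit (> 21500 nM) as the only reference. The expected step is a number no higher from compound 2 to compound 3 (the limit leaves the size open) and the most likely outcome is another limit. For compound 3 the estimate is 21500 nM with an expected range of 8000 nM to 40000 nM on this read-out.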

Compound 3, half-maximal effective concentration: > 21500 nM
Compound 3: a limit, no number; the forecaster's own chance of this, stated with the estimate: 80%; the middle value sits exactly at the limit.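

In this assay compound 3 gives > 21500 nM, a limit and not a number, so no step from compound 1 or compound 2 to compound 3 can be read: the limit of > 21500 nM in this assay, at which 3 of the 3 values shown sit.

The compounds shown leave open whether exchanging methoxy, phenyl or chloro on the shared core changes the half-maximal effective concentration at all.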